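From methyl to hydrogen on the five-membered ring

The compounds below may be only part of what the source reports. "The series", "measured", "known", "first", "only" and "open" are said of these compounds alone.

Among the compounds with values here, in a functional assay on NCI-H460 cells (Homo sapiens) for cytotoxicity, read by MTT assay, with a stated time of 72 h (a higher number here means a weaker inhibitor, a lower number a stronger inhibitor), compound 3 `Cc1[nH]cnc1/C=c1\[nH]c(=O)/c(=C/c2cccc(Oc3ccc(F)cc3)c2)[nH]c1=O` gives the highest number so far (47.6 nM), above compound 2 `CC(C)c1[nH]cnc1/C=c1\[nH]c(=O)/c(=C/c2cccc(Oc3ccc(F)cc3)c2)[nH]c1=O` (8.8 nM) and compound 1 `CC(C)(C)c1[nH]cnc1/C=c1\[nH]c(=O)/c(=C/c2cccc(Oc3ccc(F)cc3)c2)[nH]c1=O` (4 nM). Compound 4 `O=c1[nH]/c(=C\c2c[nH]cn2)c(=O)[nH]/c1=C\c1cccc(Oc2ccc(F)cc2)c1` carries hydrogen in place of methyl on an aromatic carbon, turning 5-methyl-1H-imidazol-4-yl into 1H-imidazol-4-yl. The same group shrinks across the measured steps (a 2.2-fold higher number from compound 1 to compound 2 (0.34 log units; beyond the scatter)) and (a 5.4-fold higher number from compound 2 to compound 3 (0.73 log units; beyond the scatter)), both modest, and over the whole run (a 12-fold higher number from compound 1 to compound 3 (1.08 log units; beyond the scatter)), which is large. All three compounds fit this trend, but none lacks the alkyl group altogether. A further modest rise is therefore expected in this assay (a 3.2-fold higher number from compound 3 to compound 4 (0.50 log units; beyond the scatter)). For compound 4 the estimated value is 150 nM (range from 60 nM to 400 nM).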

Compound 4, half-maximal inhibitory concentration: 479 nM
The estimate for compound 4 lay 3.2-fold (0.50 log units) below the measured number; measured number outside the range, above it.
By their numbers in this assay, from the lowest: compound 1; then compound 2; then compound 3; then compound 4.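

Within the data shown here, at this aromatic carbon the change from methyl to hydrogen is no small last step: a 10-fold higher number from compound 3 to compound 4 (1.00 log units; beyond the scatter) follows in this assay from the loss of one carbon. With no alkyl group left, the gaps reach a 54-fold higher number from compound 2 to compound 4 (1.74 log units; beyond the scatter) for the loss of isopropyl and a 120-fold higher number from compound 1 to compound 4 (2.08 log units; beyond the scatter) for the loss of tert-butyl, so the number rises at each step down in the alkyl group across all four compounds, and none goes against this. Nothing available bears on the cause of this rise. Open, as far as these compounds go, is whether an amine, a methoxy group or a chlorine atom on this carbon would keep the low numbers of the alkyl groups, and whether a cyclohexyl ring, larger than tert-butyl, would lower the number further.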